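Dropping the chlorobenzyl group from an indole nitrogen

The source may report more compounds than this note shows. Statements on the series, on what has been measured and on what is new or still open speak of the compounds shown alone.

Measured so far:
compound 1, `COc1cc(C2=NOC(c3c[nH]c4ccccc34)C2)cc(OC)c1OC`: 4510 nM
compound 2, `Clc1ccc(Cn2cc(C3CC(c4ccncc4)=NO3)c3ccccc32)cc1`: 9600 nM

In a functional assay on CWR22R cells (Homo sapiens) for inhibition, read by MTT assay, with a stated time of 48 h (on this read-out lower numbers stand for stronger inhibition and higher numbers for weaker inhibition), compound 1 gives 4510 nM and compound 2 gives 9600 nM, so compound 2 stands at the higher of the two numbers, and its gap to compound 1 lies beyond the scatter. Compound 3, `c1ccc2c(C3CC(c4ccncc4)=NO3)c[nH]c2c1`, keeps the core of compound 2 but carries hydrogen in place of 4-chlorobenzyl on an aromatic nitrogen. Within the data shown here, no step between measured compounds mirrors this change, so the direction is open; a step in this assay near the scatter or modestly weaker is expected a 1.3-fold higher number from compound 2 to compound 3 (0.10 log units; within the scatter). Compound 3 is estimated at 12000 nM, between 4000 nM and 40000 nM.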

Compound 3, half-maximal inhibitory concentration: > 100000 nM
Compound 3: a limit, no number (the forecaster's own chance of this, stated with the estimate: 15%); middle value at least 8.3-fold (0.92 log units) away from the limit.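

Hydrogen in place of 4-chlorobenzyl on the aromatic nitrogen gives, in this assay, an at least 10-fold higher number from compound 2 to compound 3 (1.01 log units; beyond the scatter). Among these compounds, this is the first view of this position, and it shows that, with the rest of compound 2 unchanged, inhibition in these cells depends heavily on the 4-chlorobenzyl group. Compound 3 gives > 100000 nM, which is a limit and not a number: the limit of > 100000 nM in this assay, at which 1 of the 3 values shown sits.

The compounds shown leave open how much of the 4-chlorobenzyl group is needed. A plain benzyl without chlorine, or a small methyl on the same nitrogen, would help separate the role of the chlorine from that of the ring.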